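The source may hold more compounds than are shown below. What is called first, only, known or untested is meant among the compounds shown, and "the series" means these compounds.

In an ADME assay on Caco-2 cells (Homo sapiens) for permeability (on this read-out lower numbers stand for lower permeability and higher numbers for higher permeability), compound 1, `CC(C)c1ccc(/C=C/C(=O)N[C@@H]2O[C@H](CO)[C@@H](O)[C@H](O)[C@H]2O)cc1`, gives 98.5 nm/s, the highest of the three numbers in hand. Compound 3, `O=C(CCc1ncc(-c2ccccc2)o1)N[C@@H]1O[C@H](CO)[C@@H](O)[C@H](O)[C@H]1O`, gives 36.5 nm/s in this assay, and compound 2, `O=C(C[C@H]1CC(=O)c2c(F)cc(F)cc21)N[C@@H]1O[C@H](CO)[C@@H](O)[C@H](O)[C@H]1O`, gives 31.7 nm/s in this assay; both gaps to compound 1 lie beyond the usual scatter. Compound 4, `O=C(/C=C/c1ccc(-c2ccccc2)cc1)N[C@@H]1O[C@H](CO)[C@@H](O)[C@H](O)[C@H]1O`, has not yet been measured. It differs from compound 1 by phenyl in place of isopropyl on an aromatic carbon. Going by the values given here, no step between two measured compounds isolates such a change, so the expectation rests on compound 1 alone: the step from compound 1 to compound 4 in this assay is expected to be a 1.2-fold higher number from compound 1 to compound 4 (0.09 log units; within the scatter), that is, small and not clearly beyond the scatter. Compound 4 is therefore estimated to give 120 nm/s in this assay, within a range from 60 nm/s to 240 nm/s.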

Compound 4, apparent permeability in the Caco-2 assay: 80.2 nm/s
Compound 4: middle estimate off by 1.5-fold (0.18 log units), on the high side; the range from low to high includes it.
By their numbers in the Caco-2 assay, from the lowest: compounds 2 and 3 (each within the scatter of the next); then compounds 4 and 1 (each within the scatter of the next).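

At this aromatic carbon, para to a large group, phenyl in place of isopropyl leaves the number in the Caco-2 assay essentially unmoved: a 1.2-fold lower number from compound 1 to compound 4 (0.09 log units; within the scatter). In a physicochemical assay for lipophilicity, measured as octanol-water partition (on this read-out higher numbers stand for higher lipophilicity and lower numbers for lower lipophilicity), compound 1 gives 0.296 and compound 4 gives 0.851. The same change therefore raises lipophilicity while permeability stays within the scatter: the measured partition coefficient of compound 1, 0.296, and of compound 4, 0.851, a number 0.56 log units higher (beyond the scatter)

What the compounds shown leave open is how an amine, a carboxylic acid or a longer alkyl chain at this carbon would read in the Caco-2 assay. On these data alone, whether phenyl and isopropyl would also read alike on another core remains open too.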